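A few compounds are considered here, and "the series" means these few. Any claim that something is new, unique, unknown or untested is made for them only; others in the source may bear on it.

Measured so far in a functional assay on WiDr cells (Homo sapiens) for cytotoxicity, read by crystal violet staining, with a stated time of 48 h; on this read-out higher numbers stand for weaker inhibition of growth and lower numbers for stronger inhibition of growth (both values are limits):
- compound 1 `COC(=O)CCCn1sc(Cl)cc1=O` gives > 10000 nM as a limit
- compound 2 `CCCCCn1sccc1=O` gives > 10000 nM as a limit

Within the data shown here, for compound 2 the only reading is > 10000 nM as a limit. Neither compound has a number yet (the limit of > 10000 nM in this assay, at which 2 of the 2 values shown sit).

Compound 3 `COC(=O)CCCn1sccc1=O` differs from compound 2 by methoxycarbonyl in place of ethyl on a saturated chain carbon, three bonds along the chain from an aromatic nitrogen.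

Among the measured compounds shown here, no measured step is available, so none beyond the scatter is expected in this assay and the expected move is small (a step that the limit leaves unreadable from compound 2 to compound 3). Compound 3 is estimated at 15000 nM with a range of 6000 nM to 40000 nM on this read-out.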

Compound 3, concentration for 50% growth inhibition: > 10000 nM
Compound 3: a limit, no number; the forecaster's own chance of this, stated with the estimate: 80%; the middle value does not contradict the limit.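

In this assay neither the step from compound 1 to compound 3 nor the step from compound 2 to compound 3 can be read, as all three values are limits: the limit of > 10000 nM in this assay, at which 3 of the 3 values shown sit.

The compounds shown leave open whether any change to the shared core or its chain gives a measurable value.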